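Shared-core urea series: stability notes ahead of compound 4

The compounds below may be only part of what the source reports. "The series", "measured", "known", "first", "only" and "open" are said of these compounds alone.

Measured compounds:
- compound 1 `O=C(NCc1cccs1)N1C(=O)c2ccccc2S1(=O)=O`: in a physicochemical assay for pharmacokinetics (on this read-out higher numbers stand for a longer-lived compound and lower numbers for a shorter-lived compound), compound 1 gives > 166 h, which is a limit of the measurement and not a number.
- compound 2 `O=C(NCc1ccccc1C(F)(F)F)N1C(=O)c2ccccc2S1(=O)=O`: in this assay compound 2 gives > 166 h, also a limit rather than a number.
- compound 3 `O=C(NCc1cccc(Br)c1)N1C(=O)c2ccccc2S1(=O)=O`: in this assay compound 3 gives > 166 h, again a limit rather than a number.

Compound 3 therefore stands at the limit in this assay; only a limit is known for it, and the two further values are limits as well, so that all three sit at the same point (the limit of > 166 h in this assay, at which 3 of the 3 values shown sit). For the measured compounds named here, the single step joining measured compounds that differ in one place, a step that the two limits leave unreadable from compound 1 to compound 3, is unreadable, both of its ends sitting at the limit (the limit of > 166 h in this assay, at which 3 of the 3 values shown sit).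

Compound 4 `Cc1ccccc1CNC(=O)N1C(=O)c2ccccc2S1(=O)=O` differs from compound 3 in one place:
2-methylphenyl in place of 3-bromophenyl on a saturated chain carbon bound to an amide-type nitrogen
Going by the values given here, no measured step covers this exchange. Among the compounds with values here, compound 2 carries yet another group on that carbon and is likewise known only as a limit, but no step to compound 2 is computed, so its value adds only that the limit recurs (the limit of > 166 h in this assay, at which 3 of the 3 values shown sit).

With every measured value at the limit (the limit of > 166 h in this assay, at which 3 of the 3 values shown sit), the step that the limit leaves unreadable from compound 3 to compound 4 is expected to show no change beyond the scatter. Compound 4 is expected to give 200 h in this assay, between 100 h and 400 h, most likely reported again only as a limit.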

Compound 4, half-life: > 166 h
Compound 4: a limit, no number; the forecaster's own chance of this, stated with the estimate: 85%; the middle value lies beyond the limit too.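

In this assay, for the compounds shown here, compound 4 is again known only as a limit, so no step joining it to compound 1, compound 2 or compound 3 can be read: the limit of > 166 h in this assay, at which 4 of the 4 values shown sit. The compounds shown leave open how far any of the four half-lives lies past that limit, and whether any group on that chain carbon shortens it.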